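Where the Triazolyl Arm Gives Way to a Piperazinylpentyl Chain

A few compounds are considered here, and "the series" means these few. Any claim that something is new, unique, unknown or untested is made for them only; others in the source may bear on it.

Compound 2 `O=C1c2c[n+]([O-])c3ccccc3c2C(=O)c2c1c1ccccc1n2Cc1cn(C[C@H](O)CO)nn1` holds the highest number of the three compounds measured in a functional assay on A549 cells (Homo sapiens) for cytotoxicity, read by MTT assay, with a stated time of 72 h; a lower number here means a stronger inhibitor, a higher number a weaker inhibitor: compound 2 gives 1030 nM. Its nearest neighbour is compound 3 `O=C1c2c[n+]([O-])c3ccccc3c2C(=O)c2c1c1ccccc1n2Cc1cn([C@H]2C[C@H](O)[C@@H](CO)O2)nn1`, which in this assay gives 350 nM, and the step of a 2.9-fold lower number from compound 2 to compound 3 (0.47 log units; beyond the scatter) is modest. Furthest from it is compound 1 `CN(C)CCCCCn1c2c(c3ccccc31)C(=O)c1c[n+]([O-])c3ccccc3c1C2=O`, which in this assay gives 210 nM, so that the step of a 4.9-fold higher number from compound 1 to compound 2 (0.69 log units; beyond the scatter) is also modest, yet beyond the scatter.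

Compound 4 `CN1CCN(CCCCCCn2c3c(c4ccccc42)C(=O)c2c[n+]([O-])c4ccccc4c2C3=O)CC1` differs from compound 2 in one place: 5-(4-methylpiperazin-1-yl)pentyl in place of 1-(2,3-dihydroxypropyl)-1H-1,2,3-triazol-4-yl on a saturated chain carbon bound to an aromatic nitrogen. For the measured compounds named here, the only measured step that bears directly on this change is a 4.9-fold higher number from compound 1 to compound 2 (0.69 log units; beyond the scatter), in which the 4-(dimethylamino)butyl chain of compound 1 was exchanged for the triazolyl arm. Compound 4 now carries a 5-(4-methylpiperazin-1-yl)pentyl chain at that same saturated chain carbon bound to an aromatic nitrogen, which is closer in kind to the chain of compound 1 than to the arm of compound 2. The step from compound 2 to compound 4 is therefore expected to run downward and to be modest, roughly undoing the earlier step. Compound 4 is expected to give about 250 nM in this assay, between 100 nM and 650 nM. The expected step is a 4.1-fold lower number from compound 2 to compound 4 (0.61 log units; beyond the scatter).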

Compound 4, half-maximal inhibitory concentration: 330 nM
For compound 4 the middle estimate is 1.3-fold (0.12 log units) below the measured one; measured number inside the range.
By their numbers in this assay, from the lowest: compounds 1, 4 and 3 (each within the scatter of the next); then compound 2.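

Placing the 5-(4-methylpiperazin-1-yl)pentyl chain where compound 2 has its triazolyl arm gives a 3.1-fold lower number from compound 2 to compound 4 (0.49 log units; beyond the scatter) in this assay, so the arm of compound 2 now stands above a second chain and not only above the 4-(dimethylamino)butyl chain of compound 1. The comparison of the two chains adds something new: with (4-methylpiperazin-1-yl)methyl in place of dimethylamino on a saturated chain carbon, five bonds along the chain from an aromatic nitrogen, there is a 1.6-fold higher number from compound 1 to compound 4 (0.20 log units; within the scatter), so this exchange leaves the number within the scatter. No measurement at hand explains either step.

From the compounds shown here alone, it remains open whether an amine at the end of the chain matters at all, which a plain hexyl chain or a chain ending in a carboxylic acid would help to settle. Going by these compounds, it is also open how a shorter chain carrying the same 4-methylpiperazin-1-yl group, or a morpholine in its place, would read in this assay.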